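This account rests on a few compounds, and the source may have more. Where it says the series, first, only, none or still open, it means among the compounds named here.

Working notes on the series, read in a functional assay on MDA-MB-436 cells (Homo sapiens) for antiproliferative activity, read by MTT assay, with a stated time of 48 h; a higher number here means a weaker inhibitor, a lower number a stronger inhibitor. Of the compounds shown here, two have numbers so far. Compound 1 (`C=CS(=O)(=O)N1CCN(c2ncnc3sc(-c4cc(Br)cnc4F)cc23)CC1`) gives 28400 nM. Compound 2 (`CCCNC(=O)N1CCN(c2ncnc3sc(-c4ccc(N5CCN(C)CC5)cc4)cc23)CC1`) gives 12400 nM, the lower of the two numbers, and the gap between them lies beyond the usual scatter. Within the data shown here, these two compounds differ in more than one place, so they offer no single-change step to calibrate against.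

Compound 3 (`COc1ccccc1NC(=O)N1CCN(c2ncnc3sc(-c4ccc(N5CCN(C)CC5)cc4)cc23)CC1`) departs from compound 2 in one place only, with 2-methoxyphenyl in place of propyl on an amide-type nitrogen. Among the measured compounds shown here, no measured pair shows what a change at this place does, so the expectation is loose and rests on the starting value of compound 2, 12400 nM, and on the size of the exchange. In this assay a moderate step toward a lower number is expected, though a result within the scatter of compound 2 would not be surprising. The estimated change is a 1.9-fold lower number from compound 2 to compound 3 (0.28 log units; within the scatter). The expected value for compound 3 is 6500 nM, with an estimated range from 2000 nM to 18000 nM.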

Compound 3, half-maximal inhibitory concentration: 26300 nM
Estimate against measurement, compound 3: 4.0-fold (0.61 log units) below; measured number above the stated range.
By their numbers in this assay, from the lowest: compound 2; then compounds 3 and 1 (each within the scatter of the next).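

Among these compounds, this is the first single-change step: in this assay, 2-methoxyphenyl in place of propyl on the amide-type nitrogen gives a 2.1-fold higher number from compound 2 to compound 3 (0.33 log units; beyond the scatter), a modest step that lies beyond the scatter. It shows that the number responds to the group on this nitrogen and that this exchange, which brings more heavy atoms, a six-membered aromatic ring of carbon only and a hydrogen-bond acceptor, moves it toward a weaker inhibitor. As the rest of the structure is shared, the step belongs to this exchange alone, although a single step gives only one direction at this place. No accompanying measurement bears on the reason for the step.

The compounds shown leave open whether the step follows from the aromatic ring or from its methoxy group, a question that an unsubstituted phenyl on the same nitrogen would address directly. They also leave open how this nitrogen tolerates a methyl group, a longer alkyl chain, or a chain ending in an amine or a carboxylic acid.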